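A few compounds are considered here, and "the series" means these few. Any claim that something is new, unique, unknown or untested is made for them only; others in the source may bear on it.

In an ADME assay on HepG2 2.2.15 cells (Homo sapiens) for cytotoxicity (on this read-out higher numbers stand for lower toxicity in this test and lower numbers for higher toxicity in this test), none of the three measured compounds shows toxicity. Compound 1 `O=C(Nc1ncc(Cc2ccc(F)cc2)s1)c1ccc(Br)cc1` gives > 50000 nM, which is a limit of the assay and not a number. Compound 2 `O=C(Nc1ncc(C(OCc2ccc(F)cc2Br)c2ccccc2)s1)c1cccs1` is reported as "not toxic" (no number reported), with no number attached. Compound 3 `CCCCC(CC)CNc1ncc(C(Oc2ccc3cc(Br)ccc3c2)c2ccc(Cl)cc2)s1` is likewise reported as "not toxic" (no number reported), again without a number, so it stands among the compounds that leave the cells unharmed in this test. The only numerical entry among the three is the limit at which compound 1 sits (the limit of > 50000 nM in this assay, at which 1 of the 3 values shown sits). Compound 4 `COC(=O)CCCCNc1ncc(C(Oc2ccc3cc(Br)ccc3c2)c2ccc(Cl)cc2)s1` has not yet been measured; it differs from compound 3 by 3-(methoxycarbonyl)propyl in place of 1-ethylpentyl on a saturated chain carbon bound to a nitrogen on an aromatic ring. For the measured compounds named here, no step between two measured compounds exists to guide the expectation, so the step from compound 3 to compound 4 in this assay is expected to be none beyond the usual scatter, in no particular direction. Compound 4 is therefore estimated to give 60000 nM in this assay, within a range from 20000 nM to 200000 nM, most likely reported once more as a limit rather than as a number.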

Compound 4, half-maximal cytotoxic concentration: "not toxic" (no number reported)
The entry for compound 4 holds no number; the estimate stays without a comparison.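

For the compounds shown here, compound 3 and compound 4 are both reported as "not toxic" with no number attached, so no step between them can be read in this assay. The compounds shown leave open at what concentration any of them would harm these cells, since the only figure is a limit: the limit of > 50000 nM in this assay, at which 1 of the 4 values shown sits.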